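The source may report more compounds than this note shows. Statements on the series, on what has been measured and on what is new or still open speak of the compounds shown alone.

In an ADME assay on L6 cells (Rattus norvegicus) for cytotoxicity, read by resazurin assay, with a stated time of 72 h (a higher number here means a weaker inhibitor, a lower number a stronger inhibitor), three compounds with a shared core have been measured. Compound 1 (`OC(c1ccc(Cl)cc1)(c1ccc(Br)cc1)c1cccnc1`) gives 57000 nM, compound 2 (`Cc1ccccc1C(O)(c1ccc(Cl)cc1)c1cccnc1`) gives 82000 nM and compound 3 (`CC(C)Oc1ccccc1C(O)(c1ccc(Cl)cc1)c1cccnc1`) gives 48300 nM. Compound 2 therefore stands within the scatter of both other compounds, and the three numbers cannot be ranked with confidence.

The next compound is compound 4 (`OC(c1ccc(Cl)cc1)(c1cccnc1)c1ccsc1`), which has not yet been measured. Its structure differs from that of compound 2 as follows: thiophen-3-yl in place of 2-methylphenyl on a saturated chain carbon bound to two aromatic carbons and an oxygen on a saturated carbon. The change is thiophen-3-yl in place of 2-methylphenyl, at the same saturated chain carbon.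

Among the measured compounds shown here, two measured steps bear on this change. The replacement of 4-bromophenyl by 2-methylphenyl at that carbon gave a 1.4-fold higher number from compound 1 to compound 2 (0.16 log units; within the scatter). The replacement of methyl by isopropoxy on an aromatic carbon gave a 1.7-fold lower number from compound 2 to compound 3 (0.23 log units; within the scatter). For the measured compounds named here, both are small, although no measured compound carries thiophen-3-yl, so neither step tests that group directly.

No step beyond the scatter is therefore expected, and the estimate is placed among the three measured values. The expected change is a 1.4-fold lower number from compound 2 to compound 4 (0.14 log units; within the scatter), which would remain within the scatter. For compound 4, the estimated value is 60000 nM, with an expected range of 30000 nM to 115000 nM.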

Compound 4, half-maximal inhibitory concentration: > 100000 nM
Compound 4 ended at the assay's limit (the forecaster's own chance of this, stated with the estimate: 5%); at least 1.6-fold (0.22 log units) between middle value and limit.
By their numbers in this assay, from the lowest: compounds 3, 1 and 2 (each within the scatter of the next). At a limit, above all of these: compound 4.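

In this assay compound 4 gives no number, only a limit of the assay: the limit of > 100000 nM in this assay, at which 1 of the 4 values shown sits.

Among the compounds shown here, with thiophen-3-yl, the only five-membered aromatic ring and the only sulfur-bearing group yet placed on this saturated chain carbon, the replacement of 2-methylphenyl reads as an at least 1.2-fold higher number from compound 2 to compound 4 (0.08 log units; that floor lies within the scatter), and the replacement of 4-bromophenyl reads as an at least 1.7-fold higher number from compound 1 to compound 4 (0.24 log units; that floor lies within the scatter). For the compounds shown here, the earlier compounds gave readable numbers at this carbon, whereas this change is the first to reach the end of the measurable range, although both floors lie within the scatter and so do not by themselves set compound 4 apart from compound 1 or compound 2.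

The compounds shown leave open how far past the limit compound 4 truly lies, and therefore whether this change is a real step beyond the scatter or no step at all. They also leave open what furan-3-yl, with an oxygen in the ring where thiophen-3-yl has sulfur, or an aminophenyl group would give at the same saturated chain carbon.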